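Morpholine in place of pyrrolidine on the thiocarbonyl carbon

A few compounds are considered here, and "the series" means these few. Any claim that something is new, unique, unknown or untested is made for them only; others in the source may bear on it.

The two measured compounds are compound 1 `N/C(=N\NC(=S)N1CCOCC1)c1ccccn1` and compound 2 `N/C(=N\NC(=S)N1CCCC1)c1ccc(F)cn1`, both tested in a functional assay on A-375 cells (Homo sapiens) for cytotoxicity, read by MTT assay, with a stated time of 72 h, tested at 10 uM; a higher number here means more inhibition of growth at the concentration tested, a lower number less inhibition of growth. In that assay compound 1 gives 18.3%, whereas compound 2 gives 82.3%. Going by the values given here, compound 2 therefore stands highest of the two numbers known; its nearest neighbour, compound 1, sits well below it, and the gap between them lies beyond the scatter. Among the compounds with values here, the two compounds differ in more than one place, so no single step between them can be read off.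

Compound 3 `N/C(=N\NC(=S)N1CCOCC1)c1ccc(F)cn1` has not yet been measured in this assay. It is reached from compound 2 by one change: morpholin-4-yl in place of pyrrolidin-1-yl on a thiocarbonyl carbon. Within the data shown here, no comparable single step has been measured here, so the size of the effect is open. Among the measured compounds shown here, compound 1, the only compound that carries morpholin-4-yl, is the weaker of the pair, which makes a downward step seem more likely than an upward one, but this rests on one compound alone. Compound 3 is estimated to give about 45%, within a range from 10% to 85%. The step expected is a number 37.3 percentage points lower from compound 2 to compound 3 (beyond the scatter).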

Compound 3, percent growth inhibition at one concentration: 70.3%
For compound 3 the middle estimate is 25.3 percentage points below the measured one; the range from low to high includes it.
By their numbers in this assay, from the lowest: compound 1; then compound 3; then compound 2.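

In this assay, morpholin-4-yl on the thiocarbonyl carbon proves compatible with strong growth inhibition: in place of pyrrolidin-1-yl it gives a number 12 percentage points lower from compound 2 to compound 3 (beyond the scatter), a modest step. The fluoro group in place of hydrogen on the aromatic carbon goes with a far larger change, a number 52 percentage points higher from compound 1 to compound 3 (beyond the scatter), so the low number of compound 1 cannot be read as the mark of morpholin-4-yl as such. Among these compounds, then, the large step lies at the aromatic carbon and the modest one at the thiocarbonyl carbon, though each rests on a single pair.

The compounds shown leave open whether the fluoro step would repeat with pyrrolidin-1-yl on the thiocarbonyl carbon, whether chloro or methoxy on the aromatic carbon would behave as fluoro does, and how piperidin-1-yl or an open-chain dimethylamino group on the thiocarbonyl carbon would compare with the two rings seen here. Nothing measured alongside these numbers speaks to the reason for either step.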